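The compounds below may be only part of what the source reports. "The series", "measured", "known", "first", "only" and "open" are said of these compounds alone.

Compound 1 `Cn1nc(Cc2nnc(SCCCCCCCC(=O)Nc3ccc(Cl)cc3Cl)n2CCCO[Si](C)(C)C(C)(C)C)c2ccccc2c1=O` carries a group of eight heavy atoms on a saturated chain carbon, three bonds along the chain from an aromatic nitrogen. In an assay on 32D cells for inhibition of interleukin-15 (Mus musculus), read by resazurin assay, with stated times of 30 min and 2.5 days, in the presence of a further agent that is not named here (a lower number here means a stronger inhibitor, a higher number a weaker inhibitor), compound 1 gives > 30000 nM, which is a limit of the assay and not a number. Compound 2 `CN(C)CCCn1c(Cc2nn(C)c(=O)c3ccccc23)nnc1SCCCCCCCC(=O)Nc1ccc(Cl)cc1Cl` differs from compound 1 in one place (a group of 3 heavy atoms (2 carbon, 1 nitrogen; no ring) in place of a group of 8 heavy atoms (6 carbon, 1 oxygen, 1 silicon; no ring), on a saturated chain carbon, three bonds along the chain from an aromatic nitrogen). In this assay compound 2 gives 3700 nM. The step is an at least 8.1-fold lower number from compound 1 to compound 2 (0.90 log units; beyond the scatter); its size is bounded only by the limit of > 30000 nM in this assay, at which 2 of the 3 values shown sit, so the true step may be larger.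

Compound 3 `Cn1c(Cc2nn(CCCO[Si](C)(C)C(C)(C)C)c(=O)c3ccccc23)nnc1SCCCCCCCC(=O)Nc1ccc(Cl)cc1Cl` is built from the same atoms as compound 1, joined differently; the difference between the two cores is not broken down here. In this assay compound 3 gives > 30000 nM, which is a limit of the assay and not a number.

Compound 4 `CN(C)CCCn1nc(Cc2nnc(SCCCCCCCC(=O)Nc3ccc(Cl)cc3Cl)n2C)c2ccccc2c1=O`, not yet measured, differs from compound 3 by the same change (a group of 3 heavy atoms (2 carbon, 1 nitrogen; no ring) in place of a group of 8 heavy atoms (6 carbon, 1 oxygen, 1 silicon; no ring), on a saturated chain carbon, three bonds along the chain from an aromatic nitrogen), at a place described in the same words as the place of the change from compound 1 to compound 2. Among the measured compounds shown here, the one measured example of this change is an at least 8.1-fold lower number from compound 1 to compound 2 (0.90 log units; beyond the scatter). The step from compound 3 to compound 4 is expected to be of the same kind, and the expected step is an at least 6.0-fold lower number from compound 3 to compound 4 (0.77 log units; beyond the scatter). This rests on a single pair, and compound 3 sits at a limit, so the outcome is uncertain. Compound 4 is expected to give about 5000 nM in this assay, with a likely range from 1500 nM to 30000 nM.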

Compound 4, half-maximal inhibitory concentration: 2300 nM
Beside the measured number, compound 4's estimate is 2.2-fold (0.34 log units) above it; measured number inside the range.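

In this assay the change from the group of 8 heavy atoms to dimethylamino, on a saturated chain carbon, three bonds along the chain from an aromatic nitrogen, carries over to a second core, giving an at least 13-fold lower number from compound 3 to compound 4 (1.11 log units; beyond the scatter), so the two examples point the same way: the same change on two cores in this assay, an at least 8.1-fold lower number (0.90 log units; beyond the scatter) from compound 1 to compound 2 and an at least 13-fold lower number (1.11 log units; beyond the scatter) from compound 3 to compound 4; the limit leaves it open whether they differ. This does not show that the change has the same size on both cores, and neither step has a known full size, as both starting compounds stand at a limit of the assay: the limit of > 30000 nM in this assay, at which 2 of the 4 values shown sit. Two cores are also too few to show that the change would carry over to any other core in this series, and the result shows only the outcome of the whole exchange, not what either group contributes on its own.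

The compounds shown leave open whether a different end group on the same chain, such as a free hydroxyl, a carboxylic acid, or another amine such as pyrrolidine or morpholine, would do the same as dimethylamino. They also leave open whether a shorter or longer chain carrying the dimethylamino group would give a different number on either core.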